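Swapping an aryl ether for a benzyl ether

The source may report more compounds than this note shows. Statements on the series, on what has been measured and on what is new or still open speak of the compounds shown alone.

Compound 1 `Clc1ccc(Oc2cncc(C3=CC4CNCC(C3)C4)c2)cc1` carries a 4-chlorophenyl on an oxygen on an aromatic ring. Among the compounds with values here, in an in vitro assay on SH-EP1 cells for displacement of a labelled ligand from Neuronal acetylcholine receptor; alpha4/beta2 (Homo sapiens) (on this read-out lower numbers stand for stronger inhibition and higher numbers for weaker inhibition), compound 1 gives 1.9 nM, the higher of the two numbers measured so far. Compound 2 `COc1cncc(C2=CC3CC(C2)CN(C)C3)c1` gives 0.6 nM in this assay, a lower number and beyond the usual scatter. Compound 3 `C1=C(c2cncc(OCc3ccccc3)c2)CC2CNCC1C2` differs from compound 1 by benzyl in place of 4-chlorophenyl on an oxygen on an aromatic ring. Within the data shown here, no measured pair shows this change, so only a small expected step, a 1.3-fold lower number from compound 1 to compound 3 (0.10 log units; within the scatter), within the scatter is assumed. Compound 3 is expected to give 1.5 nM, between 0.4 nM and 6 nM.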

Compound 3, inhibition constant: 0.7 nM
Compound 3: the middle estimate sits 2.1-fold (0.33 log units) above what was measured; measured number inside the range.
By their numbers in this assay, from the lowest: compounds 2 and 3 (each within the scatter of the next); then compound 1.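

Benzyl in place of 4-chlorophenyl on this oxygen gives a 2.7-fold lower number from compound 1 to compound 3 (0.43 log units; beyond the scatter) in this assay, a modest step. The position therefore tolerates a carbon between the oxygen and the benzene ring without losing binding, at least for this pair. No available evidence explains the step.

The swap both removes the chlorine and adds that carbon, so the two changes cannot be told apart. A plain phenyl or a 4-chlorobenzyl on the same oxygen would separate them, and a longer chain such as phenethyl would test how far the ring can move.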